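Rearranged Halophenyl Group, Half-Life Still Open

The compounds below may be only part of what the source reports. "The series", "measured", "known", "first", "only" and "open" are said of these compounds alone.

In an ADME assay on microsomes from liver (Rattus norvegicus) for metabolic stability (a lower number here means that the compound disappears faster, a higher number that the compound lasts longer), compound 1 `Nc1nc(NCCNc2ncc(-c3ncc[nH]3)c(-c3ccccc3Br)n2)ccc1[N+](=O)[O-]` gives > 0.5 h, which is a limit of the assay and not a number. Compound 2 `Nc1nc(NCCNc2ncc(-c3ncc[nH]3)c(-c3cc(F)ccc3Cl)n2)ccc1[N+](=O)[O-]` gives > 0.5 h, which is also a limit. The two compounds thus share (the limit of > 0.5 h in this assay, at which 2 of the 2 values shown sit), and compound 2 has no exact position on the scale. Compound 3 `Nc1nc(NCCNc2ncc(-c3ncc[nH]3)c(-c3ccc(Cl)cc3F)n2)ccc1[N+](=O)[O-]` has not yet been measured and differs from compound 2 by 4-chloro-2-fluorophenyl in place of 2-chloro-5-fluorophenyl on an aromatic carbon. The halogens stay the same in kind and number, and only their arrangement on the phenyl group changes. For the measured compounds named here, the one measured step that bears on this change is a step that the two limits leave unreadable from compound 1 to compound 2, so it offers no size to carry over. No step beyond the usual scatter is therefore expected, in either direction. The expected change is a step that the limit leaves unreadable from compound 2 to compound 3. For compound 3, the half-life is estimated at 0.7 h, within a range of 0.35 h to 1.4 h.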

Compound 3, half-life: > 0.5 h
Compound 3: a limit, no number; the forecaster's own chance of this, stated with the estimate: 70%; the middle value does not contradict the limit.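

In this assay compound 3 gives > 0.5 h as a limit of the assay and not a number. For the compounds shown here, compound 1, compound 2 and compound 3 all sit at this same limit, and no step among them can be read. The compounds shown leave open the actual half-life of each, and whether these halophenyl groups differ in it at all.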